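Replacing the 2-isopropyloxan-4-yl group of compound 2

A few compounds are considered here, and "the series" means these few. Any claim that something is new, unique, unknown or untested is made for them only; others in the source may bear on it.

In an ADME assay on microsomes from liver (Homo sapiens) for metabolic stability, with a stated time of 10 min (a higher number here means that more of the compound is left, a lower number that less of the compound is left), compound 2 (`COc1ccccc1-n1nc([C@@H]2CCO[C@H](C(C)C)C2)cc1-c1ccc(Cl)cc1`) gives 66%, the lower of the two numbers, and compound 1 (`COc1ccccc1-n1nc(C2CCOC(C)(C)C2)cc1-c1ccc(Cl)cc1`) gives 98%. Within the data shown here, the only measured step is large and beyond the scatter: a number 32 percentage points lower from compound 1 to compound 2 (beyond the scatter). Compound 3 (`COc1ccccc1-n1nc(C2=CC(C)(C)OC(C)(C)C2)cc1-c1ccc(Cl)cc1`) changes the group on the aromatic carbon: a group of 10 heavy atoms (9 carbon, 1 oxygen; one six-membered non-aromatic ring with 1 hetero atom) in place of a group of 9 heavy atoms (8 carbon, 1 oxygen; one six-membered non-aromatic ring with 1 hetero atom), on an aromatic carbon. Like compound 1, it carries no isopropyl group, so the reverse of a number 32 percentage points lower from compound 1 to compound 2 (beyond the scatter) is the closest guide. Among the measured compounds shown here, no measured step covers the double bond, which leaves the size uncertain. A large upward change in this assay is expected, estimated as a number 22 percentage points higher from compound 2 to compound 3 (beyond the scatter). For compound 3 the estimated value is 88%, with an expected range of 70% to 100%.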

Compound 3, percent of the compound remaining: 96%
Compound 3: middle estimate off by 8 percentage points, on the low side; low and high end bracket the measured number.
By their numbers in this assay, from the lowest: compound 2; then compounds 3 and 1 (each within the scatter of the next).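

In this assay, the group of 10 heavy atoms with 1 double bond outside aromatic rings is tolerated on this aromatic carbon: a number 30 percentage points higher from compound 2 to compound 3 (beyond the scatter), while a number 2 percentage points lower from compound 1 to compound 3 (within the scatter). Among the three compounds, only compound 2, with its 2-isopropyloxan-4-yl group, stands apart. No evidence on the origin of these differences is available.

The compounds shown do not separate the double bond from the larger group size. From the compounds shown here alone, how an amine or a carboxylic acid on this ring would behave also remains open.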